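A few compounds are considered here, and "the series" means these few. Any claim that something is new, unique, unknown or untested is made for them only; others in the source may bear on it.

Of the compounds shown here, two have so far been measured in an assay for inhibition of protein disulfide-isomerase (Homo sapiens), with a stated time of 1 h; on this read-out lower numbers stand for stronger inhibition and higher numbers for weaker inhibition. Compound 1 `COc1ccc(C(Nc2cc(C)ccn2)c2ccc3cccnc3c2O)cc1O` gives 150 nM in this assay and stands lowest of the two numbers. Compound 2 `Oc1c(C(c2ccc(F)cc2)N2CCCCC2)ccc2cncnc12`, built on a different core, gives 4860 nM in this assay, a gap from compound 1 that lies well beyond the scatter. Compound 3 `Cc1ccnc(NC(c2ccc3cccnc3c2O)c2c(F)cccc2Cl)c1` has not yet been measured. It differs from compound 1 in one place: 2-chloro-6-fluorophenyl in place of 3-hydroxy-4-methoxyphenyl on a saturated chain carbon bound to an aromatic carbon and a nitrogen on an aromatic ring. Among the compounds with values here, no pair of measured compounds differs in only one place, so a step of this kind has no direct precedent among the numbers at hand. Compound 1 sets the starting point because it gives 150 nM in this assay. The step of a 3.0-fold higher number from compound 1 to compound 3 (0.48 log units; beyond the scatter) is expected to be a modest rise in the number, close to the edge of the scatter. Compound 3 is accordingly estimated at 450 nM, within a range from 120 nM to 2000 nM.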

Compound 3, half-maximal inhibitory concentration: > 40000 nM
Compound 3 ended at the assay's limit; the forecaster's own chance of this, stated with the estimate: 5%; middle value at least 88-fold (1.94 log units) away from the limit.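

In this assay, compound 3 gives > 40000 nM, and this is a limit of the assay, not a number: the limit of > 40000 nM in this assay, at which 1 of the 3 values shown sits. With the rest of compound 1 unchanged, putting 2-chloro-6-fluorophenyl in place of 3-hydroxy-4-methoxyphenyl gives an at least 260-fold higher number from compound 1 to compound 3 (2.42 log units; beyond the scatter). Within the data shown here, this is the first single-place comparison, and it shows that the aromatic group on this saturated chain carbon strongly affects the read-out, which compounds 1 and 2 could not show because they differ in more than one place.

This one step changes the whole substitution pattern of the ring at once, so it cannot separate the loss of the hydroxy and methoxy groups from the arrival of chlorine and fluorine. From the compounds shown here alone, how an unsubstituted phenyl, a 3-hydroxyphenyl or a 4-methoxyphenyl would read at this place remains open.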